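From fluoro to hydroxy on an aromatic ring

The compounds below may be only part of what the source reports. "The series", "measured", "known", "first", "only" and "open" are said of these compounds alone.

compound 1 `Cc1occc1-c1nn2c(-c3ccncc3)nnc2s1` gives 64.7%
compound 2 `Fc1ccc(OCc2nn3c(-c4ccncc4)nnc3s2)cc1` gives 52.7%
compound 3 `c1ccc2c(C3=Nn4c(nnc4-c4ccncc4)SC3)cccc2c1` gives 69.2%

In a functional assay on BHK-21 cells (Mesocricetus auratus) for antiproliferative activity, read by sulforhodamine B assay, with a stated time of 48 h, tested at 100 uM (on this read-out lower numbers stand for less inhibition of growth and higher numbers for more inhibition of growth at the one concentration tested), compound 2 gives 52.7%, the lowest of the three numbers, and both compound 1 and compound 3 lie above it, beyond the usual scatter. The next compound, compound 4 `Oc1ccc(OCc2nn3c(-c4ccncc4)nnc3s2)cc1`, has not yet been measured. It keeps everything in compound 2 except for one place, where hydroxy stands in place of fluoro on an aromatic carbon, para to a large group, turning 4-fluorophenyl into 4-hydroxyphenyl: hydroxy in place of fluoro on an aromatic carbon.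

For the measured compounds named here, no pair of measured compounds differs in one place only, so the data hold no direct guide to this change. The three compounds differ in more than one place yet stay fairly close together, so only a modest change is anticipated. The estimated step of a number 2.3 percentage points higher from compound 2 to compound 4 (within the scatter) is expected to stay within the usual scatter, with a slight lean upward. For compound 4 the expected value is 55%, within an estimated range from 40% to 70%.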

Compound 4, percent growth inhibition at one concentration: 60.5%
Beside the measured number, compound 4's estimate is 5.5 percentage points below it, and the stated range covers the measured number.
By their numbers in this assay, from the lowest: compounds 2, 4, 1 and 3 (each within the scatter of the next, the first and the last beyond it).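

For the compounds shown here, with hydroxy in place of fluoro on an aromatic carbon, para to a large group, this assay records a number 7.8 percentage points higher from compound 2 to compound 4 (within the scatter) and so gives the first reading of a change in one place only. At the one concentration tested, the 4-fluorophenyl and 4-hydroxyphenyl forms cannot be told apart, which shows that this position accepts the exchange of these two groups without a clear effect on growth inhibition. No supporting measurement is available to account for this result.

Going by these compounds, whether an amine, a methoxy group or a carboxylic acid at this position would also stay within the scatter of compound 2 remains open. Also open, on these data alone, is whether compound 2 and compound 4 would remain alike at other concentrations.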